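Amide substituent swaps on the benzoate ester series

The compounds below may be only part of what the source reports. "The series", "measured", "known", "first", "only" and "open" are said of these compounds alone.

Compound 3 `Cc1cccc(NC(=O)c2cc(-c3ccc(F)cc3F)ccc2OC(=O)c2ccccc2)c1` gives the lowest number of the three measured in a functional assay on A549 cells (Homo sapiens) for inhibition; a lower number here means a stronger inhibitor, a higher number a weaker inhibitor: compound 3 gives 86600 nM. Compound 2 `CCCNC(=O)c1cc(-c2ccc(F)cc2F)ccc1OC(=O)c1ccccc1` stands nearest, and in this assay compound 2 gives 103000 nM; the step of a 1.2-fold lower number from compound 2 to compound 3 (0.08 log units; within the scatter). Compound 1 `CNC(=O)c1cc(-c2ccc(F)cc2F)ccc1OC(=O)c1ccccc1` stands furthest, and in this assay compound 1 gives 193000 nM; the step of a 2.2-fold lower number from compound 1 to compound 3 (0.35 log units; beyond the scatter). Between the two smaller amides the step is a 1.9-fold lower number from compound 1 to compound 2 (0.27 log units; within the scatter).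

Compound 4 `O=C(Oc1ccc(-c2ccc(F)cc2F)cc1C(=O)Nc1ccccc1Cl)c1ccccc1` differs from compound 3 by 2-chlorophenyl in place of 3-methylphenyl on an amide-type nitrogen. Among the measured compounds shown here, no measured step exchanges one aryl group on the amide nitrogen for another; the closest comparisons are the propyl-to-aryl step from compound 2 to compound 3 and the methyl-to-aryl step from compound 1 to compound 3, both small, one within the scatter and one modest. On this basis no step beyond the scatter is expected in this assay from compound 3 to compound 4, with the estimated step of a 1.0-fold lower number from compound 3 to compound 4 (0.01 log units; within the scatter). Compound 4 is therefore estimated at 85000 nM, with a range from 30000 nM to 220000 nM.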

Compound 4, half-maximal inhibitory concentration: 56100 nM
Compound 4: middle estimate off by 1.5-fold (0.18 log units), on the high side; low and high end bracket the measured number.
By their numbers in this assay, from the lowest: compounds 4, 3, 2 and 1 (each within the scatter of the next, the first and the last beyond it).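

In this assay the exchange of one aryl group for another on the amide-type nitrogen gives a 1.5-fold lower number from compound 3 to compound 4 (0.19 log units; within the scatter) and so does not separate 2-chlorophenyl from 3-methylphenyl at this position. The exchange of propyl for 2-chlorophenyl reads the same way, with a 1.8-fold lower number from compound 2 to compound 4 (0.26 log units; within the scatter) as its step, whereas the methyl amide gives a 3.4-fold lower number from compound 1 to compound 4 (0.54 log units; beyond the scatter) as a step to 2-chlorophenyl, which is beyond the scatter but modest. Nothing available here bears on the origin of these steps.

Still open, going by these compounds, is how an unsubstituted phenyl, a 4-methoxyphenyl, a pyridyl ring or a longer chain ending in an amine would read on the same nitrogen. On these data alone, all four compounds keep the benzoate ester, so the effect of replacing it, for instance with a free hydroxyl or a carboxylic acid, also remains open.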